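From naphthalen-2-yl to 4-chlorophenyl on a carbonyl carbon

A few compounds are considered here, and "the series" means these few. Any claim that something is new, unique, unknown or untested is made for them only; others in the source may bear on it.

In a functional assay on HCT-116 cells (Homo sapiens) for antiproliferative activity, read by MTT assay, with a stated time of 48 h (on this read-out higher numbers stand for weaker inhibition and lower numbers for stronger inhibition), compound 1 (`O=C(/C=C/c1ccc([N+](=O)[O-])cc1)Nc1cc(Sc2ncn[nH]2)c(O)c2ccccc12`) reads > 100000 nM as a limit of the assay. Compound 2 (`O=C(Nc1cc(Sc2ncn[nH]2)c(O)c2ccccc12)c1cccc([N+](=O)[O-])c1`) gives 70200 nM as a measured number. Compound 3 (`O=C(Nc1cc(Sc2ncn[nH]2)c(O)c2ccccc12)c1ccc2ccccc2c1`) reads > 100000 nM as a limit as well, so it stands at the limit of > 100000 nM in this assay, at which 2 of the 3 values shown sit, and has no number of its own. Compound 4 (`O=C(Nc1cc(Sc2ncn[nH]2)c(O)c2ccccc12)c1ccc(Cl)cc1`) carries 4-chlorophenyl in place of naphthalen-2-yl on a carbonyl carbon. Within the data shown here, the one measured step at this place is an at least 1.4-fold higher number from compound 2 to compound 3 (0.15 log units; that floor lies within the scatter) and gives only a floor. Among the measured compounds shown here, since compound 2 at 70200 nM is the sole number nearby, only a small move towards lower numbers is expected. The estimated step is an at least 1.2-fold lower number from compound 3 to compound 4 (0.09 log units; that floor lies within the scatter) and may not exceed the scatter. Compound 4 is estimated at 80000 nM with an expected range from 35000 nM to 150000 nM as its likely span.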

Compound 4, half-maximal inhibitory concentration: 43300 nM
For compound 4 the middle estimate is 1.8-fold (0.27 log units) above the measured one; the measured number falls inside the stated range.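

In this assay, this place on the carbonyl carbon now shows a change that lies beyond the scatter, with 4-chlorophenyl in place of naphthalen-2-yl: an at least 2.3-fold lower number from compound 3 to compound 4 (0.36 log units; beyond the scatter). That step is only a floor, because compound 3 has a limit and no number of its own: the limit of > 100000 nM in this assay, at which 2 of the 4 values shown sit. Between the two single-ring groups, 3-nitrophenyl and 4-chlorophenyl, no clear difference appears: a 1.6-fold lower number from compound 2 to compound 4 (0.21 log units; within the scatter).

On these data alone, whether an amine or a carboxylic acid in place of the chlorine would move the number further remains open.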